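What One Added Methyl Might Do to Compound 2

This account rests on a few compounds, and the source may have more. Where it says the series, first, only, none or still open, it means among the compounds named here.

In an ADME assay on KB cells (Homo sapiens) for cytotoxicity, with a stated time of 48 h (a higher number here means a weaker inhibitor, a lower number a stronger inhibitor), compound 1 (`CC1=CCC[C@](C)(CC/C(C)=C/CC2=C(O)C(=O)C=C(N[C@@H](C(=O)O)[C@@H](C)O)C2=O)[C@@H]1C`) gives > 10 ug/mL as a limit of the assay, not a number. Compound 2 (`C=C1[C@H](C)CCC[C@]1(C)CC/C(C)=C/CC1=C(O)C(=O)C=C(N[C@H](CO)C(=O)O)C1=O`) gives > 10 ug/mL as a limit too, so it has no exact value to start from. The whole record so far is the limit of > 10 ug/mL in this assay, at which 2 of the 2 values shown sit, and nothing more.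

Compound 3 (`C=C1[C@H](C)CCC[C@]1(C)CC/C(C)=C/CC1=C(O)C(=O)C=C(N[C@@H](C(=O)O)[C@@H](C)O)C1=O`) is compound 2 with one small change, methyl in place of hydrogen on a saturated chain carbon bound to an oxygen on a saturated carbon and a saturated chain carbon and nothing else. Cut one bond further out, the change reads hydroxymethyl to 1-hydroxyethyl, which turns the (1-carboxy-2-hydroxyethyl)amino group into (1-carboxy-2-hydroxypropyl)amino.

Among the measured compounds shown here, no measured pair shows what this methyl does. The expectation in this assay is therefore no shift beyond the usual scatter, in either direction, and the most likely result is another limit rather than a number. The expected change is a step that the limit leaves unreadable from compound 2 to compound 3 as an estimate only, and it is small. For compound 3 the estimated value is 15 ug/mL (expected range 7 ug/mL to 40 ug/mL).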

Compound 3, half-maximal inhibitory concentration: > 10 ug/mL
Compound 3: only a limit was reported (the forecaster's own chance of this, stated with the estimate: 85%); the middle value is on the limit's open side.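

Compound 3 gives no exact number either, so its steps from compound 2 and from compound 1 cannot be read, because all three compounds stop at the same limit: the limit of > 10 ug/mL in this assay, at which 3 of the 3 values shown sit.

From the compounds shown here alone, whether the added methyl of compound 3 changes anything in this assay stays open, and so does how far past that limit each of the three compounds lies.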